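The compounds below may be only part of what the source reports. "The series", "measured", "known", "first", "only" and "open" are said of these compounds alone.

Compound 1 `Cc1ccc(-c2cnc(N(Cc3ccccc3)Cc3ccc(C(=O)NO)cc3)s2)cc1` gives 48800 nM in a functional assay on HCT-116 cells (Homo sapiens) for antiproliferative activity, read by MTT assay, with a stated time of 48 h (a higher number here means a weaker inhibitor of growth, a lower number a stronger inhibitor of growth), the higher of the two numbers measured; compound 2 `Cc1ccc(-c2cnc(N(Cc3ccc(C(=O)NO)cc3)C(C)C)s2)cc1` gives 7800 nM. Going by the values given here, the only measured step, a 6.3-fold lower number from compound 1 to compound 2 (0.80 log units; beyond the scatter), came from putting isopropyl in place of benzyl on the nitrogen. Compound 3 `Cc1ccc(-c2cnc(N(CCCOc3ccccc3)Cc3ccc(C(=O)NO)cc3)s2)cc1` differs from compound 1 by 2-phenoxyethyl in place of phenyl on a saturated chain carbon bound to a nitrogen on an aromatic ring, so the benzyl is lengthened rather than removed, and the measured step bears on it only loosely. A step not far beyond the scatter, in either direction, is expected; compound 3 is estimated at 30000 nM, between 8000 nM and 100000 nM, meaning a 1.6-fold lower number from compound 1 to compound 3 (0.21 log units; within the scatter).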

Compound 3, concentration for 50% growth inhibition: 4140 nM
Estimate against measurement, compound 3: 7.2-fold (0.86 log units) above; the whole stated range lies above it.
By their numbers in this assay, from the lowest: compounds 3 and 2 (each within the scatter of the next); then compound 1.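

Lengthening benzyl to 3-phenoxypropyl on this nitrogen gives a 12-fold lower number from compound 1 to compound 3 (1.07 log units; beyond the scatter) and shows that a larger group here can also lower the number, which the change to the smaller isopropyl could not show. Replacing isopropyl with 3-phenoxypropyl gives a 1.9-fold lower number from compound 2 to compound 3 (0.28 log units; within the scatter) and leaves these two very different groups indistinguishable in this measurement. No supporting measurement explains either result. As far as these compounds go, it remains open whether the gain over benzyl follows the chain length or the ether oxygen, and whether a chain ending in an amine or a carboxylic acid would keep it.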